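Acetyl replacing (4-chlorophenyl)carbonyl: working note

A few compounds are considered here, and "the series" means these few. Any claim that something is new, unique, unknown or untested is made for them only; others in the source may bear on it.

Three amides of the shared core have been measured in a functional assay on NCI-H23 cells (Homo sapiens) for cytotoxicity, read by sulforhodamine B assay, with a stated time of 72 h; a lower number here means a stronger inhibitor of growth, a higher number a weaker inhibitor of growth. Compound 1 `O=C(Nc1ccccc1C(F)(F)F)C1CCc2ccccc2N1C(=O)c1ccccc1` gives 6340 nM. Compound 2 `O=C(Nc1ccccc1C(F)(F)F)C1CCc2ccccc2N1C(=O)c1ccccc1Cl` gives 2150 nM, and compound 3 `O=C(Nc1ccccc1C(F)(F)F)C1CCc2ccccc2N1C(=O)c1ccc(Cl)cc1` gives 307 nM. Compound 3 stands lowest of the three: the nearest is compound 2, a 7.0-fold lower number from compound 2 to compound 3 (0.85 log units; beyond the scatter), and the furthest is compound 1, a 21-fold lower number from compound 1 to compound 3 (1.31 log units; beyond the scatter). The smaller step is a 2.9-fold lower number from compound 1 to compound 2 (0.47 log units; beyond the scatter).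

Compound 4 `CC(=O)N1c2ccccc2CCC1C(=O)Nc1ccccc1C(F)(F)F` differs from compound 3 by methyl in place of 4-chlorophenyl on a carbonyl carbon. Among the measured compounds shown here, none of the measured steps removes the aromatic ring from the carbonyl; they only vary a chloro on it. What they show is that this part of the molecule is sensitive: changing the chloro alone moved the number by a 21-fold lower number from compound 1 to compound 3 (1.31 log units; beyond the scatter) and by a 7.0-fold lower number from compound 2 to compound 3 (0.85 log units; beyond the scatter). Taking away the whole 4-chlorophenyl removes the group that carried those gains, so a loss beyond the scatter in this assay is expected, in the direction of a higher number. Compound 1, with an unsubstituted phenyl, already gives 6340 nM, and the acetyl is expected to fall at or beyond that level.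

Compound 4 is therefore estimated at 15000 nM, within 4000 nM to 60000 nM, an expected step of a 49-fold higher number from compound 3 to compound 4 (1.69 log units; beyond the scatter).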

Compound 4, concentration for 50% growth inhibition: > 80000 nM
Compound 4: no number, only a limit; the forecaster's own chance of this, stated with the estimate: 25%; middle value at least 5.3-fold (0.72 log units) from the limit.
By their numbers in this assay, from the lowest: compound 3; then compound 2; then compound 1. At a limit, above all of these: compound 4.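

In this assay compound 4 gives no number, only a limit: the limit of > 80000 nM in this assay, at which 1 of the 4 values shown sits. With methyl in place of the aryl group on the carbonyl carbon, the steps are an at least 260-fold higher number from compound 3 to compound 4 (2.41 log units; beyond the scatter), an at least 37-fold higher number from compound 2 to compound 4 (1.57 log units; beyond the scatter) and an at least 12-fold higher number from compound 1 to compound 4 (1.10 log units; beyond the scatter). The earlier compounds shown here varied only a chloro and always kept an aromatic ring on the carbonyl, whereas the last of these steps shows that even the phenyl without any chloro stands beyond the scatter from the methyl, so the activity seen does not rest on the chloro alone.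

The compounds shown leave open whether the carbonyl needs an aromatic ring at all or whether a saturated ring such as cyclohexyl, or a longer chain such as butyl, would hold the activity that the methyl loses. They also leave open how far the gain seen with 4-chlorophenyl extends to other groups on that ring, such as a 4-methoxyphenyl, a 4-fluorophenyl or a 4-aminophenyl, and whether any of these would give a lower number than compound 3.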